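Extending the benzyl arm into an anilinoethyl chain

The source may report more compounds than this note shows. Statements on the series, on what has been measured and on what is new or still open speak of the compounds shown alone.

Compound 2 `Cc1ccc(S(=O)(=O)Nc2ccc3c(c2)C(=O)N(Cc2ccccc2)C3=O)cc1` carries a benzyl group on the ring nitrogen of the shared core. In an assay on isolated protein for inhibition of lactase/phlorizin hydrolase (Rattus norvegicus), read by colorimetric assay (a higher number here means a weaker inhibitor, a lower number a stronger inhibitor), compound 2 reaches only the limit of the measurement, given as > 200000 nM, so no number is known for it, only that it sits at that limit (the limit of > 200000 nM in this assay, at which 1 of the 2 values shown sits). Compound 1 `Cc1ccc(S(=O)(=O)Nc2ccc3c(c2)C(=O)N(CCNc2ccc(O)c(O)c2)C3=O)cc1` differs from compound 2 only in the group on that saturated chain carbon, and in this assay compound 1 gives 66600 nM. Going by the values given here, the only measured step at this place is an at least 3.0-fold higher number from compound 1 to compound 2 (0.47 log units; beyond the scatter), and its true size is unknown because one end is a limit (the limit of > 200000 nM in this assay, at which 1 of the 2 values shown sits).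

Compound 3 `Cc1ccc(S(=O)(=O)Nc2ccc3c(c2)C(=O)N(CCNc2ccccc2)C3=O)cc1` has not yet been measured. The change from compound 2 is anilinomethyl in place of phenyl on a saturated chain carbon bound to an amide-type nitrogen in a ring. Since an at least 3.0-fold higher number from compound 1 to compound 2 (0.47 log units; beyond the scatter) showed the number rising when the longer, nitrogen-bearing group was lost, restoring a longer anilino-bearing chain is expected to move the number downward, though possibly not as far as compound 1. Compound 3 is therefore expected to give about 150000 nM in this assay, within a range from 50000 nM to 400000 nM, an expected step of an at least 1.3-fold lower number from compound 2 to compound 3 (0.12 log units; that floor lies within the scatter), with a real chance that only a limit is reported again.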

Compound 3, half-maximal inhibitory concentration: 177000 nM
Compound 3: the middle estimate sits 1.2-fold (0.07 log units) below what was measured, and the stated range covers the measured number.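

Compound 3 separates two changes that were bundled together in the earlier comparison: the longer chain and the hydroxyl groups on its ring. With the 2-anilinoethyl chain held fixed, phenyl in place of 3,4-dihydroxyphenyl on the amine nitrogen gives a 2.7-fold higher number from compound 1 to compound 3 (0.42 log units; beyond the scatter), so the two hydroxyl groups matter on their own in this assay, while going from benzyl to 2-anilinoethyl without them gives an at least 1.1-fold lower number from compound 2 to compound 3 (0.05 log units; that floor lies within the scatter), which shows no gain from the longer chain alone that can be told from the scatter. The true size of that second step stays unknown, as compound 2 is a limit and not a number: the limit of > 200000 nM in this assay, at which 1 of the 3 values shown sits.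

Still open, from the compounds shown here alone, is whether a single hydroxyl group would do as well as the pair, and whether methoxy groups or a carboxylic acid on the ring could stand in for them. Also open, going by these compounds, is whether the amine nitrogen in the chain counts for anything, which an ether oxygen at that place would test, and whether the 3,4-dihydroxyphenyl ring would hold its effect on a shorter or longer chain.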